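Compound 3 to compound 4: a larger group on the carbonyl

The compounds below may be only part of what the source reports. "The series", "measured", "known", "first", "only" and "open" are said of these compounds alone.

Values in a functional assay on L5178Y cells (Mus musculus) for inhibition, read by MTT assay, with a stated time of 72 h; on this read-out higher numbers stand for weaker inhibition and lower numbers for stronger inhibition:
- Compound 1 `O=C1[Se]C(=O)c2ccccc21`: 3970 nM
- Compound 2 `COC(=O)C[Se]C(=O)c1ccc(Cl)cc1`: > 100000 nM, a limit of the assay and not a number
- Compound 3 `CC(=O)C[Se]C(=O)c1ccc(Cl)cc1`: 780 nM

Among the measured compounds shown here, compound 1 gives 3970 nM, the only other exact number, while compound 3 sits lower at 780 nM, a gap beyond the scatter. Compound 4 `CC(C)(C)C(=O)C[Se]C(=O)c1ccc(Cl)cc1` has tert-butyl in place of methyl on a carbonyl carbon. For the measured compounds named here, the one measured step at this carbonyl carbon is large: an at least 120-fold lower number from compound 2 to compound 3 (2.10 log units; beyond the scatter). That step replaced methoxy, whereas here one carbon group replaces another, so a change of that size is not expected. In this assay, the expected step is a 1.8-fold higher number from compound 3 to compound 4 (0.25 log units; within the scatter), leaning towards weaker inhibition but not clearly beyond the scatter. For compound 4 the estimate is 1400 nM, with an expected range of 300 nM to 7000 nM.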

Compound 4, half-maximal inhibitory concentration: 940 nM
Compound 4: the middle estimate sits 1.5-fold (0.17 log units) above what was measured; low and high end bracket the measured number.
By their numbers in this assay, from the lowest: compounds 3 and 4 (each within the scatter of the next); then compound 1. At a limit, above all of these: compound 2.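

In this assay, tert-butyl and methyl on this carbonyl carbon cannot be told apart (a 1.2-fold higher number from compound 3 to compound 4 (0.08 log units; within the scatter)), so the larger carbon group costs nothing measurable here. The gulf first seen with methoxy therefore holds for a second carbon group (an at least 100-fold lower number from compound 2 to compound 4 (2.02 log units; beyond the scatter)). Compound 2 carries a limit of the assay, not a number: the limit of > 100000 nM in this assay, at which 1 of the 4 values shown sits.

From the compounds shown here alone, only methyl and tert-butyl represent carbon groups at this position, so a phenyl ring or a longer chain remains open. Going by these compounds, an amine on this carbonyl carbon also remains open, as does whether it would fall closer to compound 2 or compound 4.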